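This account rests on a few compounds, and the source may have more. Where it says the series, first, only, none or still open, it means among the compounds named here.

Compound 1 `Nc1nc(CC(=O)O)n[nH]1` gives 29.5% in a functional assay on the whole organism (strain albino) for inhibition, with Rattus norvegicus as the target, read by paw edema, with stated times of 30 min and 2 h, at a dose of 5 mg/kg by the oral route; on this read-out higher numbers stand for more inhibition at the one dose given (going by the name of the read-out) and lower numbers for less inhibition. Compound 2 `CCOC(=O)Cc1nc(N)n(C(=O)c2ccccc2)n1` gives 38.5%. Compound 3 `CCOC(=O)Cc1nc(N)n(C(=O)c2ccc(Cl)cc2)n1` gives 42.3%.

In this assay compound 3 holds the highest of the three numbers shown, but compound 2 sits within the scatter of it, and only compound 1 lies beyond the scatter below it. Compound 4 `CCOC(=O)Cc1nc(N)n(C(=O)c2ccc([N+](=O)[O-])cc2)n1` differs from compound 3 by nitro in place of chloro on an aromatic carbon. Within the data shown here, the only measured step that bears on this position is a number 3.8 percentage points higher from compound 2 to compound 3 (within the scatter), a change within the scatter. No measured pair covers a nitro group, so the direction of this exchange is not anchored by any shown step. Compound 4 is therefore expected to stay near compound 3, with an expected step of a number 0.7 percentage points higher from compound 3 to compound 4 (within the scatter). Compound 4 is estimated at 43%, in a range from 30% to 56%.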

Compound 4, a percentage reported as inhibition, in the whole organism at one dose (the size of the read-out at that dose, not a potency): 46.3%
Compound 4: the middle estimate sits 3.3 percentage points below what was measured; measured number inside the range.
By their numbers in this assay, from the lowest: compounds 1, 2, 3 and 4 (each within the scatter of the next, the first and the last beyond it).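

In this assay, nitro in place of chloro gives a number 4 percentage points higher from compound 3 to compound 4 (within the scatter), and nitro in place of hydrogen gives a number 7.8 percentage points higher from compound 2 to compound 4 (within the scatter). On this aromatic carbon, para to a large group, hydrogen, chloro and nitro therefore all lie within the scatter of one another, so the three groups are not separated here. This holds for a nitro group with more heavy atoms and more hydrogen-bond acceptors than chloro.

As far as these compounds go, whether an amine or a methoxy group on this carbon would move the number beyond the scatter stays open. Nothing shown explains the numbers at this position.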